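The compounds below may be only part of what the source reports. "The series", "measured", "known", "first", "only" and "open" are said of these compounds alone.

The measured compounds so far:

Compound 1, `Cc1cc(NS(=O)(=O)c2ccc(N/C(S)=N\c3ccnc4cc(C(F)(F)F)ccc34)cc2)on1`, gives 60200 nM in a functional assay on AS49-RAW cells (Homo sapiens) for antiproliferative activity, read by sulforhodamine B assay, with a stated time of 48 h; on this read-out lower numbers stand for stronger inhibition and higher numbers for weaker inhibition.

Compound 2, `O=S(=O)(Nc1ccccn1)c1ccc(N/C(S)=N\c2ccnc3cc(C(F)(F)F)ccc23)cc1`, gives 33500 nM in this assay.

Within the data shown here, only two compounds have been measured, and they differ in just one place, the group on the sulfonamide nitrogen. That single step, a 1.8-fold lower number from compound 1 to compound 2 (0.25 log units; within the scatter), is within the usual scatter, so compound 2 and compound 1 cannot be told apart on these numbers; compound 2 simply sits at one end of a pair that behaves as one.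

Compound 3, `O=S(=O)(Nc1ncccn1)c1ccc(N/C(S)=N\c2ccnc3cc(C(F)(F)F)ccc23)cc1`, is the next compound in this series. It differs from compound 2 by pyrimidin-2-yl in place of pyridin-2-yl on a sulfonamide nitrogen. Among the measured compounds shown here, the only comparison that bears on this change is the swap of one aromatic group for another at the same nitrogen, seen in the step from compound 1 to compound 2, which was within the scatter. With one small, flat step as the whole record, no shift beyond the scatter in this assay is expected in either direction. Compound 3 is therefore estimated at 32000 nM, with a plausible range from 11000 nM to 95000 nM, which corresponds to an expected step of a 1.0-fold lower number from compound 2 to compound 3 (0.02 log units; within the scatter).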

Compound 3, half-maximal inhibitory concentration: 37800 nM
Beside the measured number, compound 3's estimate is 1.2-fold (0.07 log units) below it; low and high end bracket the measured number.
By their numbers in this assay, from the lowest: compounds 2, 3 and 1 (each within the scatter of the next).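

Placing pyrimidin-2-yl on the sulfonamide nitrogen in place of pyridin-2-yl swaps a six-membered aromatic ring with 1 hetero atom for one with 2, with the heavy-atom count unchanged at 6, and gives a 1.1-fold higher number from compound 2 to compound 3 (0.05 log units; within the scatter) in this assay. Pyrimidin-2-yl in place of 3-methyl-1,2-oxazol-5-yl gives a 1.6-fold lower number from compound 1 to compound 3 (0.20 log units; within the scatter) on the same read-out. The flat result seen for a single pair now holds across three aromatic groups at this nitrogen, and compound 1, compound 2 and compound 3 cannot be told apart on these numbers. No measurement on hand accounts for this sameness.

All three groups are aromatic rings, so these compounds do not show how a plain alkyl chain, a saturated ring such as piperidine, or a bare hydrogen on the sulfonamide nitrogen would read. They also leave open whether a ring bearing an amine or a carboxylic acid, or any change to the shared core, would move the number beyond the scatter.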